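Cyclopentyl to cyclopropyl: one more ring change

This account rests on a few compounds, and the source may have more. Where it says the series, first, only, none or still open, it means among the compounds named here.

compound 1 `O=C(Nc1ccc(Nc2nccc(NC3CCCCC3)n2)cc1)Nc1ccc(Cl)c(C(F)(F)F)c1`: 10800 nM
compound 2 `O=C(Nc1ccc(Nc2nccc(NC3CCCC3)n2)cc1)Nc1ccc(Cl)c(C(F)(F)F)c1`: 2330 nM

Going by the values given here, in a functional assay on MCF7 cells (Homo sapiens) for antiproliferative activity, read by MTT assay, with a stated time of 72 h (on this read-out higher numbers stand for weaker inhibition and lower numbers for stronger inhibition), compound 2 gives 2330 nM, the lowest number so far, which makes it the stronger inhibitor of the measured pair. The next compound, compound 3 `O=C(Nc1ccc(Nc2nccc(NC3CC3)n2)cc1)Nc1ccc(Cl)c(C(F)(F)F)c1`, keeps everything else and changes one group: cyclopropyl in place of cyclopentyl on a nitrogen on an aromatic ring. In plain words, cyclopropyl stands in place of cyclopentyl on a nitrogen on an aromatic ring.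

Among the compounds with values here, one measured step bears on this change, and it touches the same nitrogen: a 4.6-fold lower number from compound 1 to compound 2 (0.67 log units; beyond the scatter). There, cyclopentyl replaced cyclohexyl and the number fell modestly. Within the data shown here, a single step does not make a trend, and no compound with a ring as small as cyclopropyl has been measured yet. Continuing in the same direction is still the best available guess, so another modest fall is expected, although a rise would not be surprising. The estimated change is a 1.6-fold lower number from compound 2 to compound 3 (0.19 log units; within the scatter). For compound 3 the estimated value is 1500 nM, with an expected range from 500 nM to 5000 nM.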

Compound 3, half-maximal inhibitory concentration: 38300 nM
Compound 3: the middle estimate sits 26-fold (1.41 log units) below what was measured; measured number above the stated range.
By their numbers in this assay, from the lowest: compound 2; then compound 1; then compound 3.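

In this assay, the ring on this nitrogen does not follow a simple rule that smaller gives lower numbers: the earlier fall from cyclohexyl to cyclopentyl reverses at cyclopropyl, with a 16-fold higher number from compound 2 to compound 3 (1.22 log units; beyond the scatter) as a large step upward. The smallest ring also overshoots the starting point, since there is a 3.5-fold higher number from compound 1 to compound 3 (0.55 log units; beyond the scatter) as well, so of these three rings cyclopentyl gives the lowest number and both the larger and the smaller ring give higher ones. No measurement here explains why the number turns upward at cyclopropyl.

The compounds shown leave open how the number changes between the three-membered and five-membered rings, which cyclobutyl on the same nitrogen would help to trace. They also leave open whether a ring is needed here at all, a question that an open chain such as isopropyl or a longer chain such as n-pentyl could answer.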